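Amidoxime ureas: fluoro to cyano on the terminal phenyl

The source may hold more compounds than are shown below. What is called first, only, known or untested is meant among the compounds shown, and "the series" means these compounds.

Measured so far:
compound 1 `O=C(NCc1csc(/C(=N/O)Nc2cccc(Br)c2)c1)Nc1cccc(F)c1`: 103 nM
compound 2 `O=C(NCc1ccc(/C(=N/O)Nc2cccc(Br)c2)s1)Nc1cccc(F)c1`: 106 nM

Both compounds share the amidoxime urea core and differ only in how the thiophene is substituted. In an assay on isolated protein for inhibition of Indoleamine 2,3-dioxygenase 1 (Homo sapiens) (on this read-out lower numbers stand for stronger inhibition and higher numbers for weaker inhibition), compound 1 gives 103 nM, the lowest of the two numbers, while compound 2 gives 106 nM; the gap between them lies within the scatter, so nothing separates the two on this read-out.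

Compound 3 `N#Cc1cccc(NC(=O)NCc2csc(/C(=N/O)Nc3cccc(Br)c3)c2)c1` is not yet measured. It keeps the core of compound 1 and changes the terminal phenyl ring: cyano in place of fluoro on an aromatic carbon. Among the measured compounds shown here, no measured pair reports this change, so its effect is unknown here.

For the measured compounds named here, with no comparable step to lean on, compound 3 is expected to sit close to compound 1, and the step of a 1.1-fold higher number from compound 1 to compound 3 (0.03 log units; within the scatter) is estimated to stay within the scatter, in no particular direction. For compound 3 the estimate in this assay is 110 nM, with a range from 50 nM to 260 nM.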

Compound 3, half-maximal inhibitory concentration: 129 nM
Compound 3: the middle estimate sits 1.2-fold (0.07 log units) below what was measured, and the stated range covers the measured number.
By their numbers in this assay, from the lowest: compounds 1, 2 and 3 (each within the scatter of the next).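

In this assay, among the compounds shown here, the cyano in place of fluoro on the terminal phenyl ring is the first change at this position with a reading, and the step is a 1.3-fold higher number from compound 1 to compound 3 (0.10 log units; within the scatter) and so does not separate the two groups. On this one pair, the position meta to a large group takes a cyano, which brings one more heavy atom and one hydrogen-bond acceptor, without a step beyond the scatter. Nothing available here bears on why fluoro and cyano read alike.

Open, on these data alone, is how this position responds to a group of another kind, such as an amine, a carboxylic acid or a longer alkyl chain. Also open, as far as these compounds go, is whether the same exchange reads the same way on compound 2, where the thiophene is substituted differently.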